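The source may hold more compounds than are shown below. What is called first, only, known or untested is meant among the compounds shown, and "the series" means these compounds.

Compound 1 `CNCC(=O)Nc1cc(OC)ccc1C(=O)c1ccc2c(c1)C=CC(C)(C)O2` in a functional assay on HeLa cells (Homo sapiens) for antiproliferative activity, read by MTT assay, with a stated time of 48 h (on this read-out lower numbers stand for stronger inhibition and higher numbers for weaker inhibition), gives 970 nM. Compound 2 `CCNCC(=O)Nc1cc(OC)ccc1C(=O)c1ccc2c(c1)C=CC(C)(C)O2` differs from it by methyl in place of hydrogen on a saturated chain carbon bound to an amine nitrogen; in this assay compound 2 gives 3110 nM, so the step is a 3.2-fold higher number from compound 1 to compound 2 (0.51 log units; beyond the scatter). Compound 3 `C=C(c1ccc(OC)cc1NC(=O)CNC)c1ccc(OC)c2c1OC(C)(C)C=C2` is built on a different core, and the difference between the two cores is not broken down here. In this assay compound 3 gives 310 nM, the lowest of the three numbers. Compound 4 `C=C(c1ccc(OC)cc1NC(=O)CNCC)c1ccc(OC)c2c1OC(C)(C)C=C2` differs from compound 3 by methyl in place of hydrogen on a saturated chain carbon bound to an amine nitrogen, the same change at the same place as seen between compound 1 and compound 2. That change has been measured only once, on the other core, so its transfer is uncertain. For compound 4 the expected step is a 3.1-fold higher number from compound 3 to compound 4 (0.49 log units; beyond the scatter). This expectation rests on the step of a 3.2-fold higher number from compound 1 to compound 2 (0.51 log units; beyond the scatter). Compound 4 is estimated at 950 nM, ranging from 450 nM to 2200 nM.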

Compound 4, half-maximal inhibitory concentration: 1090 nM
For compound 4 the middle estimate is 1.1-fold (0.06 log units) below the measured one; low and high end bracket the measured number.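

In this assay, going from methylamino to ethylamino gives a 3.5-fold higher number from compound 3 to compound 4 (0.55 log units; beyond the scatter). Set beside the earlier step, the change carries over from one core to the other with much the same size: the same change on two cores in this assay, a 3.2-fold higher number (0.51 log units; beyond the scatter) from compound 1 to compound 2 and a 3.5-fold higher number (0.55 log units; beyond the scatter) from compound 3 to compound 4, 1.1-fold (0.04 log units) apart, within the scatter of two such steps. This rests on a single pair on each core in one cell line, so it supports transfer between these two cores only and shows nothing about a third core or another assay.

Still open, going by these compounds, is whether a primary amine or a dimethylamino group would fit the same trend on either core. On these data alone, it is also open whether a longer chain such as propylamino, or a branched one such as isopropylamino, would extend the step seen with ethylamino.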